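This account rests on a few compounds, and the source may have more. Where it says the series, first, only, none or still open, it means among the compounds named here.

Three analogues of the shared core have been measured in a functional assay on NCI-H460 cells (Homo sapiens) for cytotoxicity, read by MTT assay; on this read-out lower numbers stand for stronger inhibition and higher numbers for weaker inhibition. Compound 1 `Cc1ccc(Nc2nc(C)c(C(=O)/C=C/c3ccc(Cl)cc3)s2)cc1` carries a 4-methylphenyl on a nitrogen on an aromatic ring; in this assay compound 1 gives no number but a limit of the assay, > 25000 nM. Compound 2 `Cc1nc(Nc2cccc(Cl)c2)sc1C(=O)/C=C/c1ccc(Cl)cc1` has 3-chlorophenyl in place of 4-methylphenyl on a nitrogen on an aromatic ring; in this assay compound 2 also reaches only a limit, > 25000 nM. Compound 3 `Cc1cccc(Nc2nc(C)c(C(=O)/C=C/c3ccc(Cl)cc3)s2)c1` has 3-methylphenyl in place of 4-methylphenyl on a nitrogen on an aromatic ring; in this assay compound 3 likewise gives a limit, > 25000 nM. Compound 3 therefore stands nowhere distinct among the three: the limit of > 25000 nM in this assay, at which 3 of the 3 values shown sit, so the steps a step that the two limits leave unreadable from compound 1 to compound 3 and a step that the two limits leave unreadable from compound 2 to compound 3 cannot be read, and a step that the two limits leave unreadable from compound 1 to compound 2 is equally unreadable.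

Compound 4 `Cc1cccc(Nc2nc(C)c(C(=O)/C=C/c3ccccc3Cl)s2)c1` is the next analogue and differs from compound 3 in one place: 2-chlorophenyl in place of 4-chlorophenyl on a double-bonded chain carbon bound to a double-bonded chain carbon. Among the measured compounds shown here, none of the measured steps touches this part of the molecule, and all of them are unreadable, so neither size nor direction can be taken from them for this assay. For compound 4 the expected step of a number no higher from compound 3 to compound 4 (the limit leaves the size open) is none beyond the scatter, most probably ending again at a limit. Compound 4 is accordingly estimated at 25000 nM in this assay, within a range from 10000 nM to 60000 nM.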

Compound 4, half-maximal inhibitory concentration: > 25000 nM
Compound 4 was reported as a limit (the forecaster's own chance of this, stated with the estimate: 75%); the middle value lies on the limit itself.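

Among the compounds shown here, compound 3 and compound 4 both end at a limit of the assay, so the step between them cannot be read and no new step comes from this result: the limit of > 25000 nM in this assay, at which 4 of the 4 values shown sit. The compounds shown leave open how strongly any of them acts in this assay and whether 2-chlorophenyl and 4-chlorophenyl differ there at all.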